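The compounds below may be only part of what the source reports. "The series", "measured", "known", "first", "only" and "open" are said of these compounds alone.

Compound 2 `Clc1ccc(-c2cn3ccnc3c(-c3ccc4ncn(C5CCCCC5)c4c3)n2)cc1` stands lowest of the two compounds measured in a functional assay on MOLT-4 cells (Homo sapiens) for inhibition, read by sulforhodamine B assay, with a stated time of 48 h, tested at 10 uM; a higher number here means more inhibition at the concentration tested (going by the name of the read-out), a lower number less inhibition. In this assay, among the measured compounds shown here, compound 2 gives 8.87%, while its nearest neighbour, compound 1 `c1ccc2c(-c3cn4ccnc4c(-c4ccc5ncn(C6CCCCC6)c5c4)n3)cccc2c1`, gives 44.7%; the one step recorded, a number 35.8 percentage points lower from compound 1 to compound 2 (beyond the scatter), is large and beyond the scatter, and it arises from a single exchange of the aryl group on the shared core.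

Compound 3 `COc1ccccc1-c1cn2ccnc2c(-c2ccc3ncn(C4CCCCC4)c3c2)n1` has not been measured. Its change from compound 2 is 2-methoxyphenyl in place of 4-chlorophenyl on an aromatic carbon: the group sits at the same aromatic carbon that was exchanged between compound 1 and compound 2. For the measured compounds named here, that earlier step is the only guide. It shows that the read-out at this position responds strongly to the aryl group, but it does not tell where 2-methoxyphenyl falls between the two aryl groups already tried. The expectation is therefore a rise of modest size, a number 13.1 percentage points higher from compound 2 to compound 3 (beyond the scatter), with wide uncertainty in both directions. The estimated value for compound 3 is 22%, with a range from 3% to 50%.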

Compound 3, a percentage reported as inhibition, at one concentration (the size of the read-out at that concentration, not a potency): 22.4%
Estimate against measurement, compound 3: 0.4 percentage points below; the range from low to high includes it.
By their numbers in this assay, from the lowest: compound 2; then compound 3; then compound 1.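

In this assay, the aromatic carbon of the shared core now carries three aryl groups, and all three give clearly separate numbers. Compared with 4-chlorophenyl, 2-methoxyphenyl brings a number 13.5 percentage points higher from compound 2 to compound 3 (beyond the scatter) and, compared with naphthalen-1-yl, it brings a number 22.3 percentage points lower from compound 1 to compound 3 (beyond the scatter) and thus places compound 3 in the middle, with both steps beyond the scatter. The earlier pair showed only that this position responds strongly to the aryl group, whereas these three compounds show an intermediate level as well, with compound 1 the highest and compound 2 the lowest, and no measurement at hand accounts for this order.

The compounds shown leave open how the read-out would respond to 4-methoxyphenyl, which would carry the same methoxy group elsewhere on the ring, or to an unsubstituted phenyl, so the share of the methoxy group in the step cannot be separated from that of the chlorine. From the compounds shown here alone, it also remains open whether a phenyl ring bearing an amine or a carboxylic acid would fall inside or outside the span set by these three groups.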